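The source may hold more compounds than are shown below. What is called first, only, known or untested is meant among the compounds shown, and "the series" means these compounds.

Compounds measured so far:

Compound 1, `CN(C(=O)NC(=O)c1c(F)cccc1F)c1nc(C(F)(F)F)c(C(=O)N/N=C/c2cccc(C(F)(F)F)c2)s1`, gives 27.9 ug/mL in a functional assay on HepG2 cells (Homo sapiens) for inhibition, read by MTT assay, with a stated time of 72 h; a higher number here means a weaker inhibitor, a lower number a stronger inhibitor.
Compound 2, `Cc1nc(N(C)C(=O)NC(=O)c2c(F)cccc2F)sc1C(=O)N/N=C/c1cccc(C(F)(F)F)c1`, gives 31.6 ug/mL in this assay.
Compound 3, `CN(C(=O)NC(=O)c1cccc(C(F)(F)F)c1)c1nc(C(F)(F)F)c(C(=O)N/N=C/c2cc(C(F)(F)F)cc(C(F)(F)F)c2)s1`, gives 5.38 ug/mL in this assay.

Among these three numbers compound 1 stands second highest. Its nearest neighbour is compound 2, from which it is separated by a 1.1-fold higher number from compound 1 to compound 2 (0.05 log units; within the scatter), a step that changes only the substituent on the aromatic carbon of the shared core. Compound 3 lies furthest away, with a lower number than compound 1, but it differs from compound 1 in two places at once, so the two values can only be set side by side and not read as a single step.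

Compound 4, `CN(C(=O)NC(=O)c1ccc([N+](=O)[O-])cc1)c1nc(C(F)(F)F)c(C(=O)N/N=C/c2cccc(C(F)(F)F)c2)s1`, has not yet been measured in this assay. It differs from compound 1 in one place: 4-nitrophenyl in place of 2,6-difluorophenyl on a carbonyl carbon. For the measured compounds named here, no measured pair changes this group, so no step bears on it directly; the only single-change step available, from compound 1 to compound 2, sits elsewhere in the molecule and is within the scatter. The data therefore give no ground to expect a step beyond the scatter in either direction. The account expects compound 4 to give about 25 ug/mL, in a range from 9 ug/mL to 65 ug/mL, which as a step means a 1.1-fold lower number from compound 1 to compound 4 (0.05 log units; within the scatter), an estimate that rests on compound 1 at 27.9 ug/mL and on the absence of any bearing step.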

Compound 4, half-maximal inhibitory concentration: 4.73 ug/mL
Estimate against measurement, compound 4: 5.3-fold (0.72 log units) above; the measured number lies below the stated range.
By their numbers in this assay, from the lowest: compounds 4 and 3 (each within the scatter of the next); then compounds 1 and 2 (each within the scatter of the next).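

In this assay, the carbonyl carbon whose other neighbour is an amide-type nitrogen emerges as a place where a single change moves the number beyond the scatter: 4-nitrophenyl in place of 2,6-difluorophenyl gives a 5.9-fold lower number from compound 1 to compound 4 (0.77 log units; beyond the scatter). The only earlier single change, on an aromatic carbon of the shared core, gave a 1.1-fold higher number from compound 1 to compound 2 (0.05 log units; within the scatter) and stayed within the scatter, so this is the first step shown to alter the number, and it points towards stronger inhibition. No measurement available here accounts for the size or direction of this step.

This one swap removes the fluorines and introduces the nitro group together, so the compounds shown cannot tell whether the departure of one, the arrival of the other, or both together carries the step; an unsubstituted phenyl or an amine in place of the nitro group on the same ring would be needed to separate them. As far as these compounds go, whether the 4-nitrophenyl group has the same effect on the methyl-bearing core of compound 2 also remains open.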